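This account rests on a few compounds, and the source may have more. Where it says the series, first, only, none or still open, it means among the compounds named here.

Compounds measured so far:
- compound 1, `c1ccc(-c2cc[nH]n2)c(OCC2=NCCN2)c1`: < 100000 nM
- compound 2, `c1ccc(-c2nccs2)c(OCC2=NCCN2)c1`: 31.6 nM

Among the measured compounds shown here, in a functional assay for activation of Alpha-1D adrenergic receptor (Homo sapiens), read by calcium flux (a lower number here means that less compound is needed, a higher number that more compound is needed for the effect), compound 2 gives 31.6 nM, the only number among the two values shown. Compound 1 gives < 100000 nM, which is a limit of the assay and not a number (the limit of < 100000 nM in this assay, at which 1 of the 2 values shown sits). For the measured compounds named here, the only measured step, a step that the limit leaves unreadable from compound 1 to compound 2, therefore cannot be sized.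

Compound 3, `Cc1csc(-c2ccccc2OCC2=NCCN2)n1`, differs from compound 2 by methyl in place of hydrogen on an aromatic carbon. Going by the values given here, no measured step concerns a change of this kind: the one step that exists swaps one five-membered ring for another, and its size is unreadable. There is thus nothing to suggest a large shift in either direction, and the expectation is a step no larger than the usual scatter.

Compound 3 is therefore expected to give about 35 nM in this assay, within a range from 8 nM to 150 nM, which corresponds to an expected step of a 1.1-fold higher number from compound 2 to compound 3 (0.04 log units; within the scatter).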

Compound 3, half-maximal effective concentration: < 100000 nM
Compound 3: a limit, no number; the forecaster's own chance of this, stated with the estimate: 5%; the middle value lies beyond the limit too.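

Among the compounds shown here, neither the step from compound 2 to compound 3 nor the one from compound 1 to compound 3 can be sized, because compound 3 gives a limit of the assay and not a number: the limit of < 100000 nM in this assay, at which 2 of the 3 values shown sit.

The compounds shown leave open how large the change from 1,3-thiazol-2-yl to 4-methyl-1,3-thiazol-2-yl really is.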